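Ring methylation of the piperazine sulfonamide core: second position

The compounds below may be only part of what the source reports. "The series", "measured", "known", "first", "only" and "open" are said of these compounds alone.

Compound 1 `CC(=O)N1CCN(S(=O)(=O)c2ccc(F)cc2)CC1` is the parent of the pair measured to date. Going by the values given here, in a functional assay on the whole organism with Mus musculus as the target, with a stated time of 20 min (on this read-out lower numbers stand for an effect already at smaller amounts and higher numbers for an effect only at larger amounts of compound), compound 1 gives 0.01 mg/kg, the lowest of the two numbers; the only other measured member, compound 2 `CC(=O)N1CCN(S(=O)(=O)c2ccc(F)cc2)CC1C`, gives 1 mg/kg. Among the compounds with values here, the single step between them, a 100-fold higher number from compound 1 to compound 2 (2.00 log units; beyond the scatter), is a methyl in place of hydrogen on a saturated ring carbon, and it is a large step toward the larger-dose end of this assay.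

Compound 3 `CC(=O)N1CCN(S(=O)(=O)c2ccc(F)cc2)C(C)C1` carries the same kind of change on the other side of the ring: methyl in place of hydrogen on a saturated ring carbon. The change sits on a saturated ring carbon next to the ring nitrogen that bears the sulfonyl group, whereas in compound 2 the methyl sits on the ring carbon at the acetyl-bearing nitrogen. Within the data shown here, no measured step addresses this position directly, so the expectation rests on the one step in hand. Because a 100-fold higher number from compound 1 to compound 2 (2.00 log units; beyond the scatter) was large, a step in the same direction beyond the scatter is expected for compound 3, though a smaller one is not excluded; the step is estimated at a 30-fold higher number from compound 1 to compound 3 (1.48 log units; beyond the scatter). For compound 3 in this assay a value of 0.3 mg/kg is expected, within a range from 0.03 mg/kg to 3 mg/kg.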

Compound 3, minimum effective dose: 0.1 mg/kg
Compound 3: the middle estimate sits 3.0-fold (0.48 log units) above what was measured, and the stated range covers the measured number.
By their numbers in this assay, from the lowest: compound 1; then compound 3; then compound 2.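

In this assay, methyl in place of hydrogen on a saturated ring carbon next to the ring atom that bears a large group also moves the series toward larger doses, with a 10-fold higher number from compound 1 to compound 3 (1.00 log units; beyond the scatter). The other ring carbon gave a 100-fold higher number from compound 1 to compound 2 (2.00 log units; beyond the scatter), so the same change does not carry the same size of step at both places: it is modest here and large there, and both methyl compounds lie above compound 1, with none of the three going against this. This holds for these three compounds only, and nothing at hand bears on why the two ring carbons differ.

The compounds shown leave open whether an ethyl chain or an aminomethyl group on this ring carbon, two ring bonds from the ring atom that bears an acetyl group, would give a larger or a smaller step than methyl does. Also open, from the compounds shown here alone, is how the two steps would combine in a compound carrying a methyl on both ring carbons, since each has so far been read only singly against compound 1.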